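The compounds below may be only part of what the source reports. "The series", "measured", "known", "first", "only" and "open" are said of these compounds alone.

In a functional assay on NCI-H520 cells (Homo sapiens) for inhibition, read by MTT assay, with a stated time of 48 h, tested at 10 uM (on this read-out lower numbers stand for less inhibition and higher numbers for more inhibition at the one concentration tested (going by the name of the read-out)), compound 2 `Cc1ccc(Nc2cc(NC(=O)Nc3c(Cl)cccc3Cl)ncn2)cc1C` gives 47.5%, the highest of the two numbers shown; compound 1 `COc1cc(NC(=O)Nc2cc(Nc3ccc(C(C)(C)C)cc3)ncn2)cc(OC)c1` gives 17.5%, a gap well beyond the usual scatter. Compound 3 `COc1ccc(Nc2cc(NC(=O)Nc3c(Cl)cccc3Cl)ncn2)cc1C` has not been measured yet. It differs from compound 2 in one place: methoxy in place of methyl on an aromatic carbon. Among the measured compounds shown here, no measured pair shows this change, so the size of its step is open; a step from compound 2 to compound 3 of modest size, not clearly beyond the scatter, is expected, estimated as a number 5.5 percentage points lower from compound 2 to compound 3 (within the scatter). Compound 3 is therefore expected at about 42%, within a range from 20% to 65%.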

Compound 3, a percentage reported as inhibition, at one concentration (the size of the read-out at that concentration, not a potency): 29.1%
Estimate against measurement, compound 3: 12.9 percentage points above; low and high end bracket the measured number.
By their numbers in this assay, from the lowest: compound 1; then compound 3; then compound 2.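

Putting methoxy in place of methyl on this aromatic carbon, para to a large group, turns 3,4-dimethylphenyl into 4-methoxy-3-methylphenyl and gives in this assay a number 18.4 percentage points lower from compound 2 to compound 3 (beyond the scatter). This is the first change in a single place among the compounds shown, and it reveals that the read-out is sensitive to the group on this carbon. Nothing available explains the drop.

The compounds shown include no amine, chlorine or ethyl group on this carbon. Going by these compounds, it therefore stays open whether the lower number follows the oxygen atom or simply the larger group.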